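The compounds below may be only part of what the source reports. "The series", "measured", "known", "first", "only" and "open" are said of these compounds alone.

Working notes on the benzophenone sulfonamide series. The only numerical point so far comes from compound 1 `O=C(c1ccccc1)c1cccc(NS(=O)(=O)c2ccc(Cl)cc2Cl)c1`, which in an assay on CHO cells for binding affinity to integrin alpha-1 (Homo sapiens), read by WST assay, with a stated time of 2 h (on this read-out lower numbers stand for an effect already at smaller amounts and higher numbers for an effect only at larger amounts of compound), gives 17000 nM. Compound 2 `O=C(c1ccccc1)c1cccc(NS(=O)(=O)c2ccccc2)c1` has no single number in this assay: it is reported as "not active" (no number reported). The other isomer of the same sulfonamide, compound 3 `O=C(c1ccccc1)c1ccc(NS(=O)(=O)c2ccccc2)cc1`, likewise gives "not active" (no number reported) in this assay. So compound 2 stands among the entries without a number, alongside compound 3, while compound 1 is the one substance for which a concentration was reached at all.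

Compound 4 `Cc1ccc(S(=O)(=O)Nc2cccc(C(=O)c3ccccc3)c2)cc1` is the next candidate. Relative to compound 2 the change is methyl in place of hydrogen on an aromatic carbon, para to a large group, so that phenyl becomes 4-methylphenyl. Among the measured compounds shown here, no measured pair shows this step, so its size is unknown. Given that compound 2 gives "not active" (no number reported) and only the dichloro analogue compound 1 reaches 17000 nM, the expectation is that a single methyl leaves compound 4 close to the edge of what this assay can report, with a fair chance of no number at all. The estimate for compound 4 in this assay is 30000 nM, expected within 10000 nM to 100000 nM.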

Compound 4, half-maximal effective concentration: "not active" (no number reported)
Nothing numeric was reported for compound 4; the estimate stays without a comparison.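

No new step can be read: compound 2 and compound 4 both stand without a number in this assay, so the change from phenyl to 4-methylphenyl has no size here. No further data bear on this result. The compounds shown leave open what that change would do to a measurable value, with compound 1 at 17000 nM still the only numerical entry.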